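The source may hold more compounds than are shown below. What is called first, only, known or untested is meant among the compounds shown, and "the series" means these compounds.

Working notes on the thioether series. The shared core of compound 3 `CCCCCC(C)SCC1C2CCC(O2)C1C/C=C\CCCC(=O)O` carries a 1-methylhexyl on the sulfur, and in a functional assay on a cell-free system (plasma) with thromboxane A2 receptor (Homo sapiens) as the target (a higher number here means a weaker inhibitor, a lower number a stronger inhibitor), compound 3 gives 3800 nM, the lowest number of the three measured. Compound 1 `O=C(O)CCC/C=C\CC1C2CCC(O2)C1CSCC1CCCCC1` gives 20000 nM and compound 2 `O=C(O)CCC/C=C\CC1C2CCC(O2)C1CSC/C=C/c1ccccc1` gives 86000 nM. Against both, compound 3 stands clearly apart: a 5.3-fold lower number from compound 1 to compound 3 (0.72 log units; beyond the scatter), and a 23-fold lower number from compound 2 to compound 3 (1.35 log units; beyond the scatter). Between the two ring-bearing compounds, a 4.3-fold higher number from compound 1 to compound 2 (0.63 log units; beyond the scatter).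

Compound 4 `O=C(O)CCC/C=C\CC1C2CCC(O2)C1CSc1ccccc1` has not been measured. Its difference from compound 3 is phenyl in place of 1-methylhexyl on a sulfur. The two steps that bear on this change are those into compound 3, where a group containing a ring gave way to the 1-methylhexyl and the number fell each time, modestly from compound 1 and by a large amount from compound 2. The change to compound 4 runs the other way, a ring entering in place of the 1-methylhexyl, this time a phenyl bound straight to the sulfur without any chain. Going by the values given here, no measured pair shows this exact exchange, so the expected size is taken from the two exits from compound 3, placed between them. An increase of a 5.3-fold higher number from compound 3 to compound 4 (0.72 log units; beyond the scatter) is therefore expected. Compound 4 is estimated at 20000 nM, with a range from 6000 nM to 70000 nM.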

Compound 4, half-maximal inhibitory concentration: 13000 nM
Estimate against measurement, compound 4: 1.5-fold (0.19 log units) above, and the stated range covers the measured number.
By their numbers in this assay, from the lowest: compound 3; then compounds 4 and 1 (each within the scatter of the next); then compound 2.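

Working notes, continued. Going by these compounds alone, the step of a 3.4-fold higher number from compound 3 to compound 4 (0.53 log units; beyond the scatter) is the first direct exchange of the 1-methylhexyl for a ring bound straight to the sulfur, and it keeps compound 3 clear of all three ring-bearing compounds in this assay. The phenyl alone does not bring the high number of compound 2: with a 6.6-fold lower number from compound 2 to compound 4 (0.82 log units; beyond the scatter), removing the three-carbon unsaturated link of the 3-phenylprop-2-en-1-yl and leaving the phenyl on the sulfur gives a step beyond the scatter. The step of a 1.5-fold lower number from compound 1 to compound 4 (0.19 log units; within the scatter) shows that cyclohexylmethyl and phenyl on this sulfur cannot be told apart in this assay, so among the three ring-bearing groups only the 3-phenylprop-2-en-1-yl stands apart from the others.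

No measurement in hand accounts for any of these differences. From the compounds shown here alone, it remains open whether a longer chain than the 1-methylhexyl, a benzyl on the sulfur, or a phenyl carrying a fluorine or an amine would fall in line with compound 3 or with compound 4.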